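Where Compound 4 May Land on Lipophilicity

A few compounds are considered here, and "the series" means these few. Any claim that something is new, unique, unknown or untested is made for them only; others in the source may bear on it.

In a physicochemical assay for lipophilicity (a higher number here means a more lipophilic compound, a lower number a more polar compound), compound 3 `C=C(c1cccc2ccccc12)C1CCC2(CC1)COC(Nc1ccc(C)cc1)OO2` gives 6.08, the middle of three numbers. Compound 1 `C=C(c1cccc2ccccc12)C1CCC2(CC1)COC(Nc1ccccc1)OO2` stands lower at 5.59, and compound 2 `C=C(c1cccc2ccccc12)C1CCC2(CC1)COC(Nc1cc(Cl)cc(Cl)c1)OO2` stands higher at 6.71.

The next compound, compound 4 `C=C(c1cccc2ccccc12)C1CCC2(CC1)COC(Nc1ccccc1-c1ccccc1)OO2`, differs from compound 3 as follows: 2-phenylphenyl in place of 4-methylphenyl on an amine nitrogen. In words, it has 2-phenylphenyl in place of 4-methylphenyl on an amine nitrogen.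

Among the compounds with values here, three measured steps bear on this change. Adding a methyl gave a number 0.49 log units higher from compound 1 to compound 3 (beyond the scatter), a modest step. Placing 3,5-dichlorophenyl in place of phenyl gave a number 1.12 log units higher from compound 1 to compound 2 (beyond the scatter), a large step. Exchanging 3,5-dichlorophenyl for 4-methylphenyl gave a number 0.63 log units lower from compound 2 to compound 3 (beyond the scatter), again modest. Within the data shown here, no measured compound carries 2-phenylphenyl, so these steps offer only a guide to size. Both substituted compounds stand above compound 1, and an upward move of modest to large size is therefore expected in this assay. The expected change is a number 0.87 log units higher from compound 3 to compound 4 (beyond the scatter). For compound 4, the estimated value is 6.95, within an expected range of 6.4 to 7.5.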

Compound 4, partition coefficient: 7.26
Beside the measured number, compound 4's estimate is 0.31 log units below it; measured number inside the range.
By their numbers in this assay, from the lowest: compound 1; then compound 3; then compound 2; then compound 4.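

In this assay, 2-phenylphenyl on the amine nitrogen, with 12 heavy atoms and 2 six-membered aromatic rings where 4-methylphenyl has 7 and one, gave a number 1.18 log units higher from compound 3 to compound 4 (beyond the scatter), so this position carries a second aromatic ring and the number still rises. The same group gave a number 0.55 log units higher from compound 2 to compound 4 (beyond the scatter) and a number 1.67 log units higher from compound 1 to compound 4 (beyond the scatter), so 3,5-dichlorophenyl no longer marks the top of this short series. Nothing measured here gives a reason for the size of these steps.

Open, from the compounds shown here alone, is whether the rise depends on where the second ring sits, which 3-phenylphenyl or 4-phenylphenyl would test. Also open, going by these compounds, is how the number would read with a saturated cyclohexyl group at this position, or with a carboxylic acid or an amine on the aromatic ring.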